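A few compounds are considered here, and "the series" means these few. Any claim that something is new, unique, unknown or untested is made for them only; others in the source may bear on it.

Three compounds built on the same saturated tricyclic core differ only in the group hanging from the carbonyl carbon. Compound 1 `O=C(O)C12CCCC3CC(CCC31)C2` carries a free acid and in an ADME assay (Gallus gallus) for cytotoxicity, read by microscopy, with a stated time of 24 h (a lower number here means that less compound is tolerated, a higher number that more compound is tolerated), compound 1 gives 10000000 nM. Compound 2 `COC(=O)C12CCCC3CC(CCC31)C2` is its methyl ester, and in this assay compound 2 gives 80000 nM. Compound 3 `NC(=O)C12CCCC3CC(CCC31)C2` is the plain amide, and in this assay compound 3 gives 5200000 nM.

On these numbers compound 3 sits close to compound 1 and far from compound 2: the step of a 1.9-fold lower number from compound 1 to compound 3 (0.28 log units; within the scatter) stays inside the scatter, whereas a 65-fold higher number from compound 2 to compound 3 (1.81 log units; beyond the scatter) is a large gap. The remaining step, a 130-fold lower number from compound 1 to compound 2 (2.10 log units; beyond the scatter), shows that capping the acid with a small alkyl group lowered the tolerated concentration sharply.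

Compound 4 `CCCCNC(=O)C12CCCC3CC(CCC31)C2` is the next amide in this series: butyl in place of hydrogen on an amide-type nitrogen. Within the data shown here, the closest precedent is the alkylation step from compound 1 to compound 2, where a methyl added onto the heteroatom at the carbonyl produced a large fall; the amide of compound 3 itself was tolerated far better than the ester of compound 2. Taken together, a clearly lower number than compound 3 is expected for compound 4, smaller than the acid-to-ester drop but beyond the scatter, so that compound 4 is estimated at 400000 nM, with a range from 60000 nM to 2500000 nM, which is expected to correspond to a 13-fold lower number from compound 3 to compound 4 (1.11 log units; beyond the scatter).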

Compound 4, minimum cytotoxic concentration: 300000 nM
Compound 4: the middle estimate sits 1.3-fold (0.12 log units) above what was measured; low and high end bracket the measured number.
By their numbers in this assay, from the lowest: compound 2; then compound 4; then compounds 3 and 1 (each within the scatter of the next).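

In this assay, among these compounds, the earlier compounds only exchanged the whole group on the carbonyl carbon, whereas this result shows that the amide-type nitrogen itself is sensitive to substitution: with butyl in place of the amide hydrogen, the result is a 17-fold lower number from compound 3 to compound 4 (1.24 log units; beyond the scatter) and the step is large. Being an amide therefore does not by itself keep the number close to that of the acid, since the comparison with the acid gives a 33-fold lower number from compound 1 to compound 4 (1.52 log units; beyond the scatter) and the comparison with the methyl ester gives a 3.8-fold higher number from compound 2 to compound 4 (0.57 log units; beyond the scatter), placing compound 4 between the ester and the plain amide. Nothing available here explains why the butyl group has this effect on tolerance.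

A methyl or an octyl on the same nitrogen would show whether the number keeps falling as the chain grows or whether the fall is specific to butyl. A butyl chain ending in a carboxylic acid or an amine would show whether the fall persists when the end of the chain carries such a group.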